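Benzyl for 3-chloropropyl on two related cores

The source may hold more compounds than are shown below. What is called first, only, known or untested is meant among the compounds shown, and "the series" means these compounds.

Of the compounds shown here, three have so far been tested in a functional assay on Huh-7 cells (Homo sapiens) for cytotoxicity, read by MTT assay, with a stated time of 72 h; a lower number here means that less compound is tolerated, a higher number that more compound is tolerated. Compound 1 `O=S(=O)(CCCCl)N1CCC2(CC1)OOC1(CCCC1)OO2` and compound 2 `O=S(=O)(CCCCl)N1CCC2(CC1)OOC1(CCCCC1)OO2` carry the same 3-chloropropyl arm on the sulfonyl group but sit on two different cores; the difference between the two cores is not broken down here. In this assay compound 1 gives > 100 ug/mL, which is a limit of the assay and not a number. Compound 2 gives > 100 ug/mL, again a limit. Compound 3 `O=S(=O)(Cc1ccccc1)N1CCC2(CC1)OOC1(CCCC1)OO2` differs from compound 1 in one place: phenyl in place of 2-chloroethyl on a saturated chain carbon bound to a sulfonyl sulfur. In this assay compound 3 gives > 100 ug/mL, also a limit. The change from compound 1 to compound 3 thus yields a step that the two limits leave unreadable from compound 1 to compound 3, because both ends rest at the limit of > 100 ug/mL in this assay, at which 3 of the 3 values shown sit.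

Compound 4 `O=S(=O)(Cc1ccccc1)N1CCC2(CC1)OOC1(CCCCC1)OO2` has not yet been measured. It stands to compound 2 as compound 3 stands to compound 1: phenyl in place of 2-chloroethyl on a saturated chain carbon bound to a sulfonyl sulfur. The place of the change is the same in both pairs, so it is the same change. Within the data shown here, since every measured value in this assay sits at the limit of > 100 ug/mL in this assay, at which 3 of the 3 values shown sit, there is no sized step to carry across. Compound 4 is expected to give around 150 ug/mL, most probably again as a limit, within a range from 70 ug/mL to 400 ug/mL. The step that the limit leaves unreadable from compound 2 to compound 4 is accordingly expected to be small, an expectation that rests on a step that the two limits leave unreadable from compound 1 to compound 3.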

Compound 4, half-maximal cytotoxic concentration: > 100 ug/mL
Compound 4 ended at the assay's limit (the forecaster's own chance of this, stated with the estimate: 85%); the middle value does not contradict the limit.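

No size can be read for the step from compound 2 to compound 4, because both compounds sit at the same limit of this assay and neither gives a number: the limit of > 100 ug/mL in this assay, at which 4 of the 4 values shown sit.

The compounds shown leave open how much of any of them the cells tolerate, and whether benzyl in place of 3-chloropropyl makes any difference on either core.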